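Swapping Benzyloxy for Nitro on the Shared Core

This account rests on a few compounds, and the source may have more. Where it says the series, first, only, none or still open, it means among the compounds named here.

Measured so far:
compound 1, `Nc1nc(O)c2c(n1)n(C1OC(CO)[C@@H](O)[C@H]1O)c(=O)n2Cc1ccc(OCc2ccccc2)cc1` — 6%
compound 2, `C=CCn1c(=O)n(C2C=CC(CO)O2)c2nc(N)nc(O)c21` — 89%

In a functional assay on YAC-1 cells (Mus musculus) (a higher number here means a larger maximal response, a lower number a smaller maximal response), compound 1 gives 6%, the lowest of the two numbers shown. Compound 2 gives 89% in this assay, a number that lies far above compound 1, beyond the usual scatter. Among the compounds with values here, the two compounds differ in several places at once, so no single step between measured compounds is known, and the size of any one change cannot be read from them.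

Compound 3, `Nc1nc(O)c2c(n1)n(C1OC(CO)[C@@H](O)[C@H]1O)c(=O)n2Cc1ccc([N+](=O)[O-])cc1`, differs from compound 1 in one place: nitro in place of benzyloxy on an aromatic carbon. With compound 1 sitting close to the floor, a further drop has little room, while the change leaves most of the molecule untouched. A small to moderate rise in maximal response is expected, a number 14 percentage points higher from compound 1 to compound 3 (beyond the scatter). Compound 3 is therefore expected to give 20% in this assay, within a range from 3% to 55%.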

Compound 3, largest response reached (reported as maximal response), in percent of the reference or control that the assay uses: 50%
Beside the measured number, compound 3's estimate is 30 percentage points below it, and the stated range covers the measured number.
By their numbers in this assay, from the lowest: compound 1; then compound 3; then compound 2.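

In this assay, nitro in place of benzyloxy on an aromatic carbon gives a number 44 percentage points higher from compound 1 to compound 3 (beyond the scatter) with the rest of the molecule unchanged, which makes this a large step. Within the data shown here, this is the first comparison here that isolates a single change, and it shows that the maximal response depends strongly on the group at this position, para to a large group. The swap replaces a group of 8 heavy atoms that carries an aromatic ring with one of 3 heavy atoms and no ring, but no measurement shown here explains why the response rises.

Still open, from the compounds shown here alone, is whether the rise follows from losing the benzyloxy group or from gaining the nitro group. An amine or a methoxy group at this position would help tell these two readings apart.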